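Trifluoromethyl for chloro on two chalcone piperazine cores

A few compounds are considered here, and "the series" means these few. Any claim that something is new, unique, unknown or untested is made for them only; others in the source may bear on it.

Three chalcone piperazines have been tested, and a fourth waits on the same measurement. Compound 1 `O=C(/C=C/c1ccccc1)c1ccc(N2CCN(c3cccc(Cl)c3)CC2)cc1` and compound 2 `O=C(/C=C/c1ccccc1)c1ccc(N2CCN(c3cccc(C(F)(F)F)c3)CC2)cc1` share one core; in a functional assay on the whole organism (strain Kunming) for inhibition, with Mus musculus as the target, with a stated time of 1 h, at a dose of 40 mg/kg by the oral route (a higher number here means more inhibition at the dose given (going by the name of the read-out), a lower number less inhibition), compound 1 gives 14.1% and compound 2 gives 25%. The change between them is trifluoromethyl in place of chloro on an aromatic carbon, and it made a step of a number 10.9 percentage points higher from compound 1 to compound 2 (beyond the scatter). Compound 3 `O=C(/C=C/c1ccc(Cl)cc1)c1ccc(N2CCN(S(=O)(=O)c3ccc(Cl)cc3)CC2)cc1` sits on a different core, one in which the second aryl ring is joined through a sulfonyl group; in this assay compound 3 gives 56.6%, the highest of the three, with the other two beyond the scatter below it. The difference between the two cores is not broken down here.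

Compound 4 `O=C(/C=C/c1ccc(Cl)cc1)c1ccc(N2CCN(S(=O)(=O)c3ccc(C(F)(F)F)cc3)CC2)cc1` is built from compound 3 by trifluoromethyl in place of chloro on an aromatic carbon. This is the same kind of change as that from compound 1 to compound 2, but not the same: in the earlier pair the group sat meta to a large group, whereas here it sits para to a large group. Because the earlier step was a number 10.9 percentage points higher from compound 1 to compound 2 (beyond the scatter), a modest rise of similar size is expected here, though on a different core and at a different place the match is uncertain. The step from compound 3 to compound 4 in this assay is expected to be a number 7.4 percentage points higher from compound 3 to compound 4 (within the scatter). Compound 4 is therefore estimated to give 64%, between 50% and 78%.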

Compound 4, a percentage reported as inhibition, in the whole organism at one dose (the size of the read-out at that dose, not a potency): 59.6%
Estimate against measurement, compound 4: 4.4 percentage points above; the measured number falls inside the stated range.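

In this assay, within the data shown here, replacing 4-chlorophenyl with 4-(trifluoromethyl)phenyl on the sulfonyl-linked core gave a number 3 percentage points higher from compound 3 to compound 4 (within the scatter), so this change produced no step that can be told from repeated measurement on that core. Set beside the earlier step, the new one does not differ from it by more than measurements of this kind would allow: the same change on two cores in this assay, a number 10.9 percentage points higher (beyond the scatter) from compound 1 to compound 2 and a number 3 percentage points higher (within the scatter) from compound 3 to compound 4, 7.9 percentage points apart, within the scatter of two such steps. Among these compounds, this shows that the two pairs are compatible with a single modest effect of the change, but it does not establish one, as only two pairs are available, the group does not sit at the same place in both, and only the earlier step lies beyond the scatter.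

The compounds shown leave open how other groups at the place held by trifluoromethyl, such as a methoxy group, a nitrile or an amine, would read in this assay. They also leave open how much of the gap between the two cores belongs to the sulfonyl link and how much to the chloro group on the other terminal ring of compound 3, as no pair shown separates these two features.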